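Lengthening a Chain on a Shared Core

This account rests on a few compounds, and the source may have more. Where it says the series, first, only, none or still open, it means among the compounds named here.

Measured compounds:
- compound 1, `C=C(C)CCC[C@]1(C)C2=CCC[C@](C)(CC(=O)c3ccoc3)[C@H]2CC[C@H]1C`: > 100000 nM
- compound 2, `C=C(C)CCC[C@]1(C)C2=CCC[C@](C)(C[C@H](O)c3ccoc3)[C@H]2CC[C@H]1C`: 31200 nM
- compound 3, `C=C(C)CC[C@]1(C)C2=CCC[C@](C)(C[C@@H](O)C3=CC(=O)OC3O)[C@H]2CC[C@H]1C`: 3300 nM

In a functional assay on HL-60 cells (Homo sapiens) for antiproliferative activity, read by XTT assay, with a stated time of 72 h (a lower number here means a stronger inhibitor, a higher number a weaker inhibitor), compound 1 gives only a limit, > 100000 nM, not a number. Compound 2, which differs from compound 1 by an at least 3.2-fold lower number from compound 1 to compound 2 (0.50 log units; beyond the scatter), gives 31200 nM. Compound 3 gives 3300 nM, the lowest of the two numbers shown; the nearest number, that of compound 2, is higher beyond the scatter, and the two share no single-place step.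

Compound 4, `C=C(C)CCC[C@]1(C)C2=CCC[C@](C)(C[C@@H](O)C3=CC(=O)OC3O)[C@H]2CC[C@H]1C`, differs from compound 3 only by 2-methylprop-2-en-1-yl in place of 1-methylethenyl on a saturated chain carbon, two bonds along the chain from a saturated ring carbon. Among the measured compounds shown here, the one measured step, an at least 3.2-fold lower number from compound 1 to compound 2 (0.50 log units; beyond the scatter), concerns a different part of the molecule and says nothing about lengthening this chain. For the measured compounds named here, no measured step bears on the change, so no shift beyond the scatter is expected in this assay in either direction.

Compound 4 is therefore estimated at 3300 nM, within 1200 nM to 9000 nM, which means an expected step of no change at the digits printed from compound 3 to compound 4 (within the scatter).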

Compound 4, half-maximal inhibitory concentration: 3200 nM
Estimate against measurement, compound 4: 1.0-fold (0.01 log units) above, within the range that was stated.
By their numbers in this assay, from the lowest: compounds 4 and 3 (each within the scatter of the next); then compound 2. At a limit, above all of these: compound 1.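

In this assay, 2-methylprop-2-en-1-yl in place of 1-methylethenyl, on a saturated chain carbon two bonds along the chain from a saturated ring carbon, gives a 1.0-fold lower number from compound 3 to compound 4 (0.01 log units; within the scatter), so these two chains cannot be told apart in this assay. With the longer chain in place, the five-membered non-aromatic ring group can be set directly against the furan-bearing group with its hydroxyl, and it gives a 9.8-fold lower number from compound 2 to compound 4 (0.99 log units; beyond the scatter). Set against the furan-bearing group with its carbonyl, the same ring group gives an at least 31-fold lower number from compound 1 to compound 4 (1.49 log units; beyond the scatter), and that size is only a bound: the limit of > 100000 nM in this assay, at which 1 of the 4 values shown sits.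

On these data alone, whether the number stays flat with a still longer chain, such as 3-methylbut-3-en-1-yl or 4-methylpent-4-en-1-yl, remains open. So does the effect of a saturated chain, or of an amine or a carboxylic acid, in place of 2-methylprop-2-en-1-yl.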